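The compounds below may be only part of what the source reports. "The series", "measured", "known", "first", "only" and "open" are said of these compounds alone.

In a functional assay on THP-1 cells (Homo sapiens) for cytotoxicity, read by MTT assay, with a stated time of 24 h (on this read-out lower numbers stand for stronger inhibition and higher numbers for weaker inhibition), the three measured compounds stand as follows:

Compound 1, `CN1C/C(=C\c2ccc(Cl)cc2)C(=O)/C(=C/c2cccc([N+](=O)[O-])c2)C1`, gives 7870 nM.
Compound 2, `CN1C/C(=C\c2ccc(Br)cc2)C(=O)/C(=C/c2cccc([N+](=O)[O-])c2)C1`, gives 7690 nM.
Compound 3, `CN1C/C(=C\c2ccc(Cl)cc2)C(=O)/C(=C/c2ccc(C#N)cc2)C1`, gives 3180 nM.

Compound 1 and compound 2 differ in one place only, (bromo in place of chloro on an aromatic carbon). The step between them is a 1.0-fold lower number from compound 1 to compound 2 (0.01 log units; within the scatter), so the two numbers are not told apart by this assay.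

Compound 3 carries a different core. The difference between the core of compound 1 and the core of compound 3 is not broken down here. What the values show is that compound 3 gives the lowest number of the three, and its gaps to compound 1 and to compound 2 both lie beyond the scatter.

Compound 4, `CN1C/C(=C\c2ccc(Br)cc2)C(=O)/C(=C/c2ccc(C#N)cc2)C1`, has not yet been measured in this assay. It differs from compound 3 by bromo in place of chloro on an aromatic carbon. This is the same change as the one from compound 1 to compound 2, made at the same place on the same kind of ring, and no other pair among the compounds shown carries it. The step from compound 3 to compound 4 is therefore expected to be small, a 1.0-fold lower number from compound 3 to compound 4 (0.01 log units; within the scatter), because a 1.0-fold lower number from compound 1 to compound 2 (0.01 log units; within the scatter) showed no separation beyond the scatter on the other core. Compound 4 is accordingly estimated at 3100 nM in this assay, with a likely range from 1600 nM to 6200 nM. With a single prior instance of the change, the range is kept broad.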

Compound 4, half-maximal inhibitory concentration: 4400 nM
Compound 4: the middle estimate sits 1.4-fold (0.15 log units) below what was measured, within the range that was stated.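

In this assay, replacing the 4-chlorophenyl group with a 4-bromophenyl group on the core of compound 3 gives a 1.4-fold higher number from compound 3 to compound 4 (0.14 log units; within the scatter), so this pair, like the earlier one, is not told apart by the assay. Set side by side, the two steps show that the change behaves alike on both cores, with no difference between them that can be separated from the scatter: the same change on two cores in this assay, a 1.0-fold lower number (0.01 log units; within the scatter) from compound 1 to compound 2 and a 1.4-fold higher number (0.14 log units; within the scatter) from compound 3 to compound 4, 1.4-fold (0.15 log units) apart, within the scatter of two such steps. This supports treating bromo and chloro as interchangeable at this place for these two cores in this one cytotoxicity read-out, but two pairs do not show that this holds on other cores, on the other aromatic ring or in other assays, and they give no explanation of the result.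

The compounds shown leave open whether a group other than chloro or bromo at this place, such as fluoro, methoxy, an amine or a carboxylic acid, would move the number beyond the scatter. Also open, as far as these compounds go, is how far the number depends on the nitro and nitrile groups on the other aromatic ring, and whether a longer chain in place of the methyl on the ring nitrogen would change it.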